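Pyridin-4-yl in place of phenyl: working notes

The compounds below may be only part of what the source reports. "The series", "measured", "known", "first", "only" and "open" are said of these compounds alone.

Within the data shown here, in a functional assay on MDA-MB-231 cells (Homo sapiens) for cytotoxicity, read by MTT assay, with a stated time of 72 h (a lower number here means a stronger inhibitor, a higher number a weaker inhibitor), compound 2 `O=C(CN1CCN(c2nnc(Cc3ccccc3)c3ccccc23)CC1)Nc1ccc(F)c(C(F)(F)F)c1` gives 760 nM, the higher of the two numbers measured so far. Compound 1 `O=C(CN1CCN(c2nnc(Cc3ccncc3)c3ccccc23)CC1)Nc1cccc(Br)c1` gives 1.7 nM in this assay, and the gap between the two lies well beyond the scatter.

Compound 3 `O=C(CN1CCN(c2nnc(Cc3ccncc3)c3ccccc23)CC1)Nc1ccc(F)c(C(F)(F)F)c1` keeps everything in compound 2 except one group: pyridin-4-yl in place of phenyl on a saturated chain carbon bound to an aromatic carbon. In words, pyridin-4-yl stands in place of phenyl on a saturated chain carbon bound to an aromatic carbon, so benzyl becomes (pyridin-4-yl)methyl.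

Among the measured compounds shown here, no measured pair isolates this exchange, and compound 1 also differs from compound 2 at the amide end, so the size of the step remains uncertain. For the measured compounds named here, the only guide is compound 1, which carries the same pyridin-4-yl group and gives 1.7 nM. A move to a lower number in this assay, beyond the scatter but covering only part of the gap between the two measured compounds, is expected. The expected change is a 15-fold lower number from compound 2 to compound 3 (1.18 log units; beyond the scatter). For compound 3 the estimated value is 50 nM, with an expected range from 6 nM to 400 nM.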

Compound 3, half-maximal inhibitory concentration: 1.9 nM
Beside the measured number, compound 3's estimate is 26-fold (1.42 log units) above it; the whole stated range lies above it.
By their numbers in this assay, from the lowest: compounds 1 and 3 (each within the scatter of the next); then compound 2.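

In this assay, pyridin-4-yl in place of phenyl on a saturated chain carbon bound to an aromatic carbon now has a matched pair, and the exchange alone gives a large step (a 400-fold lower number from compound 2 to compound 3 (2.60 log units; beyond the scatter)). With pyridin-4-yl held constant, 4-fluoro-3-(trifluoromethyl)phenyl in place of 3-bromophenyl on an amide-type nitrogen gives no separation (a 1.1-fold higher number from compound 1 to compound 3 (0.05 log units; within the scatter)), so in this pair the change of aryl group on the amide side has no readable effect on the number, and the exchange at the chain carbon is the one that moves it. The exchange swaps a ring of carbon only for a ring with 1 hetero atom and adds 1 hydrogen-bond acceptor, but no measurement available here explains the size of the step.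

Among these compounds, the only pair for this exchange carries 4-fluoro-3-(trifluoromethyl)phenyl on the amide-type nitrogen, so the size of the step with other groups there remains open. Also open, as far as these compounds go, is how pyridin-3-yl, pyridin-2-yl or a longer chain between the core and the pyridine ring would compare with pyridin-4-yl on its single carbon.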